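The source may report more compounds than this note shows. Statements on the series, on what has been measured and on what is new or still open speak of the compounds shown alone.

Measured in a functional assay on K562 cells (Homo sapiens), read by MTT assay, with a stated time of 72 h (on this read-out lower numbers stand for stronger inhibition and higher numbers for weaker inhibition), each value a limit and not a number:

- Compound 1 `COc1nc(N)nc2c1c(-c1ccco1)cn2[C@@H]1O[C@H](CO)[C@@H](O)[C@H]1O` (> 20000 nM)
- Compound 2 `COc1nc(N)nc2c1c(-c1ccoc1)cn2[C@@H]1O[C@H](CO)[C@@H](O)[C@H]1O` (> 20000 nM)
- Compound 3 `COc1nc(N)nc2c1c(-c1cccs1)cn2[C@@H]1O[C@H](CO)[C@@H](O)[C@H]1O` (> 20000 nM)

Compound 3 has no number on this read-out, only its limit (> 20000 nM). It shares that limit with both other measured compounds (the limit of > 20000 nM in this assay, at which 3 of the 3 values shown sit).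

Compound 4 `COc1nc(N)nc2c1c(-c1ccsc1)cn2[C@@H]1O[C@H](CO)[C@@H](O)[C@H]1O` carries thiophen-3-yl in place of thiophen-2-yl on an aromatic carbon.

The closest measured parallel is furan-3-yl in place of furan-2-yl (a step that the two limits leave unreadable from compound 1 to compound 2). The two exchanges of a furan for thiophen-2-yl also bear on it (a step that the two limits leave unreadable from compound 1 to compound 3; a step that the two limits leave unreadable from compound 2 to compound 3). None of these three steps has a readable size, so they give neither a size nor a direction for the new change.

In this assay no shift beyond the scatter is therefore expected, and a further limit is the likeliest report. The expected step stays within the scatter (a number no higher from compound 3 to compound 4 (the limit leaves the size open)).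

The estimate for compound 4 is 20000 nM, with an expected range from 8000 nM to 40000 nM.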

Compound 4, half-maximal inhibitory concentration: > 20000 nM
Compound 4 was reported as a limit (the forecaster's own chance of this, stated with the estimate: 85%); the middle value sits exactly at the limit.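

No step linking compound 4 with compound 1, compound 2 or compound 3 can be read in this assay, as all four stand at a limit of the assay: the limit of > 20000 nM in this assay, at which 4 of the 4 values shown sit.

On these data alone, whether furan-2-yl, furan-3-yl, thiophen-2-yl and thiophen-3-yl differ from one another in this assay stays open.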